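The compounds below may be only part of what the source reports. "The series", "measured", "known", "first", "only" and "open" are said of these compounds alone.

Of the compounds shown here, three built on one shared core have been measured in an ADME assay on MEpiC cells (Homo sapiens) for antiproliferative activity, read by MTT assay, with a stated time of 48 h; on this read-out higher numbers stand for weaker inhibition and lower numbers for stronger inhibition. Compound 1 `O=C1C=CC2(C=C1)OC(=O)C(c1cc3ccccc3o1)=C2c1ccccc1` gives 66600 nM, the highest of the three numbers and therefore the weakest inhibition among them. Compound 2 `COc1ccc(C2=C(c3ccccc3)C3(C=CC(=O)C=C3)OC2=O)cc1` gives 11700 nM, and compound 3 `COc1cc(C2=C(c3ccccc3)C3(C=CC(=O)C=C3)OC2=O)cc(OC)c1OC` gives 6610 nM, the lowest of the three. Going by the values given here, the one step that can be read between direct neighbours is a 5.7-fold lower number from compound 1 to compound 2 (0.76 log units; beyond the scatter), in which the 1-benzofuran-2-yl group gives way to a 4-methoxyphenyl group.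

Compound 4 `O=C1C=CC2(C=C1)OC(=O)C(c1ccc(C(=O)O)cc1)=C2c1ccccc1` has not yet been measured. It differs from compound 1 by 4-carboxyphenyl in place of 1-benzofuran-2-yl on a double-bonded ring carbon. The step from compound 1 to compound 2 bears on this change, since there too a 1-benzofuran-2-yl group left and a substituted phenyl entered on the same double-bonded ring carbon, and the number fell by a modest amount. Compound 4, however, carries a 4-carboxyphenyl group rather than a 4-methoxyphenyl group, so that step is a guide and not a copy. For compound 4 a lower number is expected, with a step of a 1.9-fold lower number from compound 1 to compound 4 (0.28 log units; within the scatter), smaller than the measured one. Compound 4 is therefore estimated at 35000 nM in this assay, within a range from 10000 nM to 90000 nM.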

Compound 4, half-maximal inhibitory concentration: 10400 nM
Beside the measured number, compound 4's estimate is 3.4-fold (0.53 log units) above it, within the range that was stated.
By their numbers in this assay, from the lowest: compounds 3, 4 and 2 (each within the scatter of the next); then compound 1.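

In this assay, a 6.4-fold lower number from compound 1 to compound 4 (0.81 log units; beyond the scatter) shows that the fall seen with 4-methoxyphenyl in place of 1-benzofuran-2-yl on this double-bonded ring carbon is not confined to that one group, as 4-carboxyphenyl also gives a number lower than that of compound 1. Carboxy in place of methoxy on the aromatic carbon gives a 1.1-fold lower number from compound 2 to compound 4 (0.05 log units; within the scatter) and so leaves no difference that can be read, even though the two groups are quite different in structure. Nothing measured alongside these numbers explains either step.

An amine on the phenyl ring, or the methyl ester of the carboxylic acid, could show whether this tolerance extends further. On these data alone, it also remains open how a simple alkyl chain would fare at this position, with no aromatic ring there at all.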